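The source may report more compounds than this note shows. Statements on the series, on what has been measured and on what is new or still open speak of the compounds shown alone.

Of the compounds shown here, three of one family have been tested in an assay on isolated protein for inhibition of DNA topoisomerase 1 (Homo sapiens), with a stated time of 15 min; a higher number here means a weaker inhibitor, a lower number a stronger inhibitor. Compound 1 `NC[C@@H]1CCN(c2cc3c(cc2F)c(=O)c(C(=O)O)cn3Cc2nc(-c3ccncc3)no2)C1` gives only a limit in this assay, reported as > 200000 nM. Compound 2 `COc1c(N2CC[C@@H](CN)C2)c(F)cc2c(=O)c(C(=O)O)cn(Cc3ccc(-n4cccn4)cc3)c12` likewise gives only a limit, reported as > 200000 nM. Compound 3 `CNCCNc1cc2c(cc1F)c(=O)c(C(=O)O)cn2Cc1ccc(-c2ccccc2)cc1` also returns only a limit, reported as > 200000 nM. Compound 3 therefore cannot be placed above or below its companions on the numbers shown: every value is a limit, and the single piece of evidence is the limit of > 200000 nM in this assay, at which 3 of the 3 values shown sit.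

Compound 4 `O=C(O)c1cn(Cc2ccc(-c3ccccc3)cc2)c2cc(NC[C@H]3CCNC3)c(F)cc2c1=O` has not yet been measured. It differs from compound 3 in one place: pyrrolidin-3-yl in place of (methylamino)methyl on a saturated chain carbon bound to a nitrogen on an aromatic ring. No step between two measured compounds exists that would anchor this change to a shift in this assay, so nothing in the numbers shown points either up or down. The author expects no movement beyond the scatter, and the step from compound 3 to compound 4 is estimated at a number no higher from compound 3 to compound 4 (the limit leaves the size open). Compound 4 is accordingly expected to give about 200000 nM in this assay, within a range from 60000 nM to 400000 nM, and most probably to be reported once more only as a limit rather than as a number.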

Compound 4, half-maximal inhibitory concentration: 100000 nM
For compound 4 the middle estimate is 2.0-fold (0.30 log units) above the measured one; the measured number falls inside the stated range.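

Pyrrolidin-3-yl in place of (methylamino)methyl, on a saturated chain carbon bound to a nitrogen on an aromatic ring, gives the first step in this family that can be read in this assay: an at least 2.0-fold lower number from compound 3 to compound 4 (0.30 log units; that floor lies within the scatter). As far as these compounds go, the step has only a floor, and its true size stays unknown since compound 3 gave a limit and not a number. Compound 4 is the only compound of the four to give a number, which shows that this position can bring a measurable reading in this assay, while the other compounds remain at a limit: the limit of > 200000 nM in this assay, at which 3 of the 4 values shown sit.

The compounds shown do not tell whether the ring itself, its two added heavy atoms or its defined stereocentre accounts for the reading, and the opposite stereoisomer of compound 4 would help to separate these. They also leave open how a piperidin-3-yl or an azetidin-3-yl group would read at this place, and whether pyrrolidin-3-yl would give a number with the other side chains on the ring nitrogen of the core, as in compound 1 and compound 2.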